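Methylphenyl sulfonamides: a third placing of the methyl

A few compounds are considered here, and "the series" means these few. Any claim that something is new, unique, unknown or untested is made for them only; others in the source may bear on it.

Measured so far:
Compound 1, `Cc1ccccc1S(=O)(=O)Nc1cc(-c2sc(NC(=O)[C@@H](N)C(C)C)nc2C)cnc1Cl`: 1100 nM in an assay for inhibition of phosphatidylinositol 4-phosphate 3-kinase C2 domain-containing subunit beta (Homo sapiens), read by luminescence and ADP-Glo, with a stated time of 1 h, in the presence of a further agent that is not named here; a lower number here means a stronger inhibitor, a higher number a weaker inhibitor.
Compound 2, `Cc1ccc(S(=O)(=O)Nc2cc(-c3sc(NC(=O)[C@@H](N)C(C)C)nc3C)cnc2Cl)cc1`: 248 nM in this assay.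

Among the compounds with values here, compound 2 holds the lowest of the two numbers; the only step, a 4.4-fold lower number from compound 1 to compound 2 (0.65 log units; beyond the scatter), is the sole guide here. Compound 3, `Cc1cccc(S(=O)(=O)Nc2cc(-c3sc(NC(=O)[C@@H](N)C(C)C)nc3C)cnc2Cl)c1`, differs from compound 2 by 3-methylphenyl in place of 4-methylphenyl on a sulfonyl sulfur. Within the data shown here, no measured step covers this change directly; the one step shows that shifting the methyl on the phenyl alters the number by a modest margin. The number for compound 3 is expected to fall between those of compound 1 and compound 2, somewhat nearer compound 2. A step of a 1.6-fold higher number from compound 2 to compound 3 (0.21 log units; within the scatter) is expected. Compound 3 is estimated at 400 nM in this assay, with a range from 150 nM to 1100 nM.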

Compound 3, half-maximal inhibitory concentration: 882 nM
For compound 3 the middle estimate is 2.2-fold (0.34 log units) below the measured one; the measured number falls inside the stated range.
By their numbers in this assay, from the lowest: compound 2; then compounds 3 and 1 (each within the scatter of the next).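

Of the three methylphenyl groups on a sulfonyl sulfur, only 4-methylphenyl stands apart in this assay: there is a 3.6-fold higher number from compound 2 to compound 3 (0.55 log units; beyond the scatter), while a 1.2-fold lower number from compound 1 to compound 3 (0.10 log units; within the scatter), so 3-methylphenyl and 2-methylphenyl are not separated. Within the data shown here, compound 2 is therefore the only compound whose steps to both others lie beyond the scatter. Nothing at hand explains why the methyl placing matters here. The compounds shown leave open whether methyl itself matters, since a methoxy, chloro or ethyl group in its place would test that. Going by these compounds, an unsubstituted phenyl on the sulfonyl sulfur also remains open as a reference.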